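Amide substituent changes on the shared core: cytotoxicity notes

A few compounds are considered here, and "the series" means these few. Any claim that something is new, unique, unknown or untested is made for them only; others in the source may bear on it.

Compound 3 `O=C(NCCO)c1c(NO)cc(-c2ccccc2)oc1=O` in an ADME assay on Huh-7 cells (Homo sapiens) for cytotoxicity, read by a luciferase reporter and WST assay, with a stated time of 3 days (on this read-out higher numbers stand for lower toxicity in this test and lower numbers for higher toxicity in this test), gives > 20000 nM, which is a limit of the assay and not a number. The same holds for its two neighbours: compound 1 `CCNC(=O)c1c(NO)cc(-c2ccccc2)oc1=O` in this assay gives > 20000 nM, a limit, and compound 2 `CC(C)NC(=O)c1c(NO)cc(-c2ccccc2)oc1=O` in this assay gives > 20000 nM, also a limit. The three steps between them are accordingly a step that the two limits leave unreadable from compound 1 to compound 2, a step that the two limits leave unreadable from compound 1 to compound 3 and a step that the two limits leave unreadable from compound 2 to compound 3; the position of all three values is summed up by the limit of > 20000 nM in this assay, at which 3 of the 3 values shown sit.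

Compound 4 `O=C(NCc1ccccc1)c1c(NO)cc(-c2ccccc2)oc1=O` differs from compound 3 by phenyl in place of hydroxymethyl on a saturated chain carbon bound to an amide-type nitrogen. Among the measured compounds shown here, none of the measured steps gives a readable size for any change on the amide nitrogen, so no direction beyond the scatter can be expected in this assay from the step of a number no higher from compound 3 to compound 4 (the limit leaves the size open). The expectation for compound 4 in this assay is therefore 20000 nM, with a range from 7000 nM to 60000 nM, and most likely again only a limit will be reported.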

Compound 4, half-maximal cytotoxic concentration: > 20000 nM
Compound 4: only a limit was reported (the forecaster's own chance of this, stated with the estimate: 65%); the middle value lies on the limit itself.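

Compound 4 in this assay gives > 20000 nM, a limit and not a number. Among the compounds shown here, no step from compound 1, compound 2 or compound 3 to compound 4 can be read. Whether any amide substituent on the shared core changes the half-maximal cytotoxic concentration stays open, with every value at one point: the limit of > 20000 nM in this assay, at which 4 of the 4 values shown sit.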